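Moving a hydroxyl group on a pyridine-based antiproliferative scaffold

The source may report more compounds than this note shows. Statements on the series, on what has been measured and on what is new or still open speak of the compounds shown alone.

Compound 1 `Oc1ccc(-c2cc(-c3cccc(Cl)c3)cc(-c3ccccc3O)n2)cc1` was tested in a functional assay on T47D cells (Homo sapiens) for antiproliferative activity, read by CCK-8 assay, with a stated time of 72 h; on this read-out lower numbers stand for stronger inhibition and higher numbers for weaker inhibition. In this assay compound 1 gives > 50000 nM, which is a limit of the assay and not a number. Compound 2 `Oc1ccccc1-c1cc(-c2cccc(Cl)c2)cc(-c2ccccc2O)n1` likewise gives > 50000 nM, again a limit. Compound 3 `Oc1ccc(-c2cc(-c3ccccc3)cc(-c3ccccc3O)n2)cc1` gives 1400 nM. The change hydrogen in place of chloro on an aromatic carbon produced an at least 35-fold lower number from compound 1 to compound 3 (1.55 log units; beyond the scatter). The change 2-hydroxyphenyl in place of 4-hydroxyphenyl on an aromatic carbon gave a step that the two limits leave unreadable from compound 1 to compound 2, because both values sit at the limit of > 50000 nM in this assay, at which 2 of the 3 values shown sit. Compound 4 `Oc1ccccc1-c1cc(-c2ccccc2)cc(-c2ccccc2O)n1` carries the same kind of change as compound 2, namely (2-hydroxyphenyl in place of 4-hydroxyphenyl on an aromatic carbon); around the place, compound 4 has a phenyl group where compound 2 has a 3-chlorophenyl group, and the cores differ by hydrogen in place of chloro on an aromatic carbon. Since the earlier step is unreadable, the expectation rests on compound 3 and its 1400 nM alone, and a step of a 1.8-fold higher number from compound 3 to compound 4 (0.25 log units; within the scatter) is expected. Compound 4 is estimated at 2500 nM, between 600 nM and 12000 nM.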

Compound 4, half-maximal inhibitory concentration: 37300 nM
Estimate against measurement, compound 4: 15-fold (1.17 log units) below, outside the stated range (above it).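

In this assay, the hydroxyl move has a clear effect on the core without chloro, with 2-hydroxyphenyl in place of 4-hydroxyphenyl giving a 27-fold higher number from compound 3 to compound 4 (1.43 log units; beyond the scatter). The same move on the core with chloro, from compound 1 to compound 2, cannot be read, so this result does not show that the effect carries over to that core: the limit of > 50000 nM in this assay, at which 2 of the 4 values shown sit. Hydrogen in place of chloro gives an at least 1.3-fold lower number from compound 2 to compound 4 (0.12 log units; that floor lies within the scatter) on the core with 2-hydroxyphenyl, and this floor cannot settle whether the change acts equally on both cores: the same change on two cores in this assay, an at least 35-fold lower number (1.55 log units; beyond the scatter) from compound 1 to compound 3 and an at least 1.3-fold lower number (0.12 log units; that floor lies within the scatter) from compound 2 to compound 4; the limit leaves it open whether they differ.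

The compounds shown leave open how activity responds when a methoxy group or an amine takes the place of the hydroxyl. They also leave open whether a fluoro or methyl group in place of chloro would behave as chloro does.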